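Methyl on the ring nitrogen of a small acid fragment

This account rests on a few compounds, and the source may have more. Where it says the series, first, only, none or still open, it means among the compounds named here.

Compound 1 `C=C(Br)C(=O)Nc1ccc2oc(C(=O)NCCNC(=O)c3cc(OCC4(c5ccc(-c6ccccc6)cc5)CC(=C)C(=O)O4)nn3C)cc2c1`: 270 nM
Compound 2 `C=C(Br)C(=O)Nc1ccc2sc(C(=O)NCCNC(=O)c3cc(OCC4(c5ccc(Cl)cc5)CC(=C)C(=O)O4)nn3C)cc2c1`: 260 nM
Compound 3 `C=C(Br)C(=O)Nc1ccc2[nH]c(C(=O)O)cc2c1`: 4300 nM

In a functional assay on L1210 cells (Mus musculus) for antiproliferative activity (on this read-out lower numbers stand for stronger inhibition and higher numbers for weaker inhibition), compound 3 gives 4300 nM, the highest of the three numbers. The nearest is compound 1 with 270 nM, a gap that lies beyond the scatter, and compound 2 with 260 nM stands further still. Compound 3 is a small acid fragment, while compounds 1 and 2 carry long extensions on the shared core.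

Compound 4 `C=C(Br)C(=O)Nc1ccc2c(c1)cc(C(=O)O)n2C` differs from compound 3 by methyl in place of hydrogen on an aromatic nitrogen. Going by the values given here, no pair of measured compounds shows this change, so nothing in the data fixes its size. Within such a small fragment a change of one carbon is expected to move this assay little, and the step from compound 3 to compound 4 is estimated to stay within the scatter, in either direction a 1.1-fold lower number from compound 3 to compound 4 (0.03 log units; within the scatter). Compound 4 is therefore expected at 4000 nM, in a range from 1500 nM to 12000 nM.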

Compound 4, half-maximal inhibitory concentration: 2070 nM
For compound 4 the middle estimate is 1.9-fold (0.29 log units) above the measured one, within the range that was stated.
By their numbers in this assay, from the lowest: compounds 2 and 1 (each within the scatter of the next); then compound 4; then compound 3.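

In this assay, methyl in place of hydrogen on the aromatic nitrogen gives a 2.1-fold lower number from compound 3 to compound 4 (0.32 log units; beyond the scatter) in this small acid fragment, so this position responds to substitution, though only modestly. This is the first change in a single place among these compounds; compounds 1 and 2 differ from compound 3 in more than one place and could not show what this nitrogen contributes. Nothing in the data accounts for the step.

An ethyl group or a longer chain on this nitrogen could show whether the step continues beyond methyl, and a primary amide in place of the carboxy group would test the neighbouring group. From the compounds shown here alone, whether the same methyl step holds in compounds carrying long extensions also remains open.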